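A few compounds are considered here, and "the series" means these few. Any claim that something is new, unique, unknown or untested is made for them only; others in the source may bear on it.

Measured in a physicochemical assay for solubility; on this read-out lower numbers stand for lower solubility and higher numbers for higher solubility:
- compound 1 `O=C(c1ccc(C(F)(F)F)cc1)N1CCC(NS(=O)(=O)c2cc(S(=O)(=O)c3ccccc3)ccc2C(F)(F)F)CC1`: 6300 nM
- compound 2 `O=C(O)CCCC(=O)N1CCC(NS(=O)(=O)c2cc(S(=O)(=O)c3ccccc3)ccc2C(F)(F)F)CC1`: 50000 nM

Compound 2 holds the higher of the two numbers, at 50000 nM. Among the measured compounds shown here, only one measured step bears on what follows: a 7.9-fold higher number from compound 1 to compound 2 (0.90 log units; beyond the scatter). That step was made on the same carbonyl carbon, with the rest of the molecule unchanged.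

Compound 3 `CC(C)(C)OC(=O)N1CCC[C@H]1C(=O)N1CCC(NS(=O)(=O)c2cc(S(=O)(=O)c3ccccc3)ccc2C(F)(F)F)CC1` keeps the shared core and differs from compound 2 at that one place, on a carbonyl carbon whose other neighbour is an amide-type nitrogen in a ring: 1-(tert-butoxycarbonyl)pyrrolidin-2-yl in place of 3-carboxypropyl on a carbonyl carbon. In words, 1-(tert-butoxycarbonyl)pyrrolidin-2-yl stands in place of 3-carboxypropyl.

For the measured compounds named here, no measured compound carries the entering group, so the forecast rests on a single comparison. Compound 3 gives up the 3-carboxypropyl group, which came with the higher number in a 7.9-fold higher number from compound 1 to compound 2 (0.90 log units; beyond the scatter). A fall of similar size is therefore expected, back towards compound 1 at 6300 nM.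

In this assay the expected change is a 5.0-fold lower number from compound 2 to compound 3 (0.70 log units; beyond the scatter). For compound 3 the estimated value is 10000 nM, with an expected range of 3000 nM to 30000 nM.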

Compound 3, solubility: 25000 nM
Compound 3: middle estimate off by 2.5-fold (0.40 log units), on the low side; measured number inside the range.
By their numbers in this assay, from the lowest: compound 1; then compounds 3 and 2 (each within the scatter of the next).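

In this assay, among the compounds shown here, the new result shows that 3-carboxypropyl is not the only group on this carbonyl carbon that can hold a high number: a 2.0-fold lower number from compound 2 to compound 3 (0.30 log units; within the scatter) leaves the two with no readable difference. This holds although the entering 1-(tert-butoxycarbonyl)pyrrolidin-2-yl has 12 heavy atoms, a five-membered ring and 0 hydrogen-bond donors, where 3-carboxypropyl has 6 heavy atoms, no ring and 1 hydrogen-bond donor. With a 4.0-fold higher number from compound 1 to compound 3 (0.60 log units; beyond the scatter) added, 4-(trifluoromethyl)phenyl stands apart as the group with the lowest number of the three at this place, although nothing at hand explains these numbers.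

The compounds shown leave open which part of the entering group goes with its number, since the tert-butoxycarbonyl group, the pyrrolidine ring and the defined stereocentre arrive together, and a pyrrolidine with a free ring amine would begin to separate them. They also leave open whether a plain phenyl ring, without trifluoromethyl, or a simple alkyl chain without a carboxylic acid would sit with compound 1 or with the other two.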